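From 2-nitrophenyl to 3-nitrophenyl on a shared core

This account rests on a few compounds, and the source may have more. Where it says the series, first, only, none or still open, it means among the compounds named here.

In a functional assay on K562 cells (Homo sapiens) for cytotoxicity, read by sulforhodamine B assay (a higher number here means that more compound is tolerated, a lower number that less compound is tolerated), compound 3 `CC1=CC[C@@H]([C@@](C)(O)CCCC(C)(C)NC(=S)N/N=C\c2ccccc2[N+](=O)[O-])CC1` stands at > 100000 nM as a limit and not a number. Compound 1 `COc1ccc(/C=N\NC(=S)NC(C)(C)CCC[C@](C)(O)[C@@H]2CC=C(C)CC2)cc1` gives > 100000 nM as a limit too. Compound 2 `CC1=CC[C@@H]([C@@](C)(O)CCCC(C)(C)NC(=S)N/N=C\c2ccc(O)cc2)CC1` gives > 100000 nM as a limit as well. For the measured compounds named here, the evidence so far comes down to the limit of > 100000 nM in this assay, at which 3 of the 3 values shown sit, and no compound in the set has yet given a number.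

Compound 4 `CC1=CC[C@@H]([C@@](C)(O)CCCC(C)(C)NC(=S)N/N=C\c2cccc([N+](=O)[O-])c2)CC1` keeps the shared core and changes one thing, 3-nitrophenyl in place of 2-nitrophenyl on a carbon with a double bond to nitrogen with 3-nitrophenyl in place of 2-nitrophenyl on a carbon with a double bond to nitrogen. The two compounds have the same atoms, joined differently.

The closest measured changes replace the group on that same carbon. They give a step that the two limits leave unreadable from compound 1 to compound 3 and a step that the two limits leave unreadable from compound 2 to compound 3 while the change on the oxygen gives a step that the two limits leave unreadable from compound 1 to compound 2 as well. None of these steps has a readable size, so none offers a number to carry over. In this assay the expected result is a number no higher from compound 3 to compound 4 (the limit leaves the size open) with no step beyond the scatter expected and no direction favoured. Compound 4 is estimated at 100000 nM with an expected range from 30000 nM to 200000 nM and will most likely be reported as a limit again.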

Compound 4, concentration lethal to 50% of the cells: 12600 nM
Compound 4: middle estimate off by 7.9-fold (0.90 log units), on the high side, and the stated range ends above it.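

In this assay, for the compounds shown here, 3-nitrophenyl on the carbon with a double bond to nitrogen gives the only number in the set, showing that this place can change the read-out, which the earlier compounds could not show. The change from 2-nitrophenyl to 3-nitrophenyl keeps the same atoms, joined differently, yet gives an at least 7.9-fold lower number from compound 3 to compound 4 (0.89 log units; beyond the scatter), so the arrangement within this group matters here and not only its atoms; the replacements of the other two groups give an at least 7.9-fold lower number from compound 2 to compound 4 (0.89 log units; beyond the scatter) and an at least 7.9-fold lower number from compound 1 to compound 4 (0.89 log units; beyond the scatter). The steps among the three earlier compounds cannot be read, and those compounds remain at a limit and not a number: the limit of > 100000 nM in this assay, at which 3 of the 4 values shown sit.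

From the compounds shown here alone, the true size of all three new steps stays open, since each starts from a limit and could be larger than printed. Also open, going by these compounds, is whether the gain belongs to the nitro group itself or would hold for another group in the same arrangement, such as 3-aminophenyl or 3-carboxyphenyl, and whether 4-nitrophenyl would behave like 3-nitrophenyl or like 2-nitrophenyl.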